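Ester in place of hydroxypropyl ether on the quinone side chain

This account rests on a few compounds, and the source may have more. Where it says the series, first, only, none or still open, it means among the compounds named here.

Measured compounds:
compound 1 `CCC(O)CO[C@H](CC=C(C)C)C1=CC(=O)c2c(O)ccc(O)c2C1=O` gives 28700 nM in a functional assay on HeLa cells (Homo sapiens) for cytotoxicity, read by MTT assay; on this read-out higher numbers stand for weaker inhibition and lower numbers for stronger inhibition
compound 2 `CC(C)=CC[C@@H](OCC(C)O)C1=CC(=O)c2c(O)ccc(O)c2C1=O` gives 24700 nM in this assay

The account follows the step from compound 2 to compound 3. Compound 2 stands with the lowest of the two numbers shown, but its only neighbour is compound 1, and the step of a 1.2-fold lower number from compound 1 to compound 2 (0.07 log units; within the scatter) lies within the scatter, so the two compounds cannot be told apart on these data. Compound 3 `CC(C)=CC[C@@H](OC(=O)C1CCCOC1)C1=CC(=O)c2c(O)ccc(O)c2C1=O` is not yet measured. It differs from compound 2 in one place: (oxan-3-yl)carbonyl in place of 2-hydroxypropyl on an oxygen on a saturated carbon. For the measured compounds named here, the one measured step, a 1.2-fold lower number from compound 1 to compound 2 (0.07 log units; within the scatter), touches only a methyl on the side chain and says nothing about an ester or a ring entering here. Going by the values given here, no measured step therefore bears on the change to compound 3, and the expectation rests on compound 2 alone. Compound 3 is expected to give about 25000 nM, within 6000 nM to 100000 nM, a step of a 1.0-fold higher number from compound 2 to compound 3 (0.01 log units; within the scatter) that is itself only an estimate.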

Compound 3, half-maximal inhibitory concentration: 60500 nM
For compound 3 the middle estimate is 2.4-fold (0.38 log units) below the measured one, within the range that was stated.
By their numbers in this assay, from the lowest: compounds 2 and 1 (each within the scatter of the next); then compound 3.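

In this assay, (oxan-3-yl)carbonyl in place of 2-hydroxypropyl on this oxygen gives a 2.4-fold higher number from compound 2 to compound 3 (0.39 log units; beyond the scatter), and the same group in place of 2-hydroxybutyl gives a 2.1-fold higher number from compound 1 to compound 3 (0.32 log units; beyond the scatter). The earlier methyl step stayed within the scatter, whereas these two modest steps show that replacing the whole group on this oxygen does move the number, and that the move is towards weaker inhibition. Nothing measured here accounts for that shift.

The compounds shown change the carbonyl and the ring together, and an acetyl group or an oxan-3-yl ether on the same oxygen would tell the two apart. On these data alone, how an amine or a carboxylic acid at the end of the chain on this oxygen would read in this assay also remains open.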